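From Cyclopentyl to Pyrrolidin-1-yl on a Sulfonyl Sulfur

A few compounds are considered here, and "the series" means these few. Any claim that something is new, unique, unknown or untested is made for them only; others in the source may bear on it.

In an ADME assay on a cell-free system (plasma, Rattus norvegicus) for protein binding, using equilibrium dialysis (a higher number here means a larger unbound share of the compound, a lower number a smaller unbound share), compound 1 (`O=S(=O)(c1ccc(O)c2ncccc12)C1CCCC1`) gives 0.5 and compound 3 (`O=S(=O)(c1cc(Cl)c(O)c2ncccc12)C1CCCC1`) gives 0.5 as its reading, while compound 2 (`O=S(=O)(c1cc(F)c(O)c2ncccc12)C1CCCC1`) gives 0.2 as the lowest of the three. The measured steps that reach compound 2 are a 2.5-fold lower number from compound 1 to compound 2 (0.40 log units; beyond the scatter) and a 2.5-fold higher number from compound 2 to compound 3 (0.40 log units; beyond the scatter), and the remaining one is no change at the digits printed from compound 1 to compound 3 (within the scatter) as a comparison. Compound 4 (`O=S(=O)(c1cc(F)c(O)c2ncccc12)N1CCCC1`) differs from compound 2 in one place: pyrrolidin-1-yl in place of cyclopentyl on a sulfonyl sulfur, which is pyrrolidin-1-yl in place of cyclopentyl on a sulfonyl sulfur. Among the compounds with values here, no measured step touches that place. All three exchange groups on an aromatic carbon, so they offer a scale of size but no direction for this change. Compound 2 stands at the low end with 0.2 in this assay, so a small rise seems likelier than a further fall. The expected change is a 1.5-fold higher number from compound 2 to compound 4 (0.18 log units; within the scatter), smaller than the modest steps seen so far. For compound 4 the estimated value is 0.3, with an expected range from 0.13 to 0.6.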

Compound 4, unbound fraction: 0.6
The estimate for compound 4 lay 2.0-fold (0.30 log units) below the measured number; low and high end bracket the measured number.
By their numbers in this assay, from the lowest: compound 2; then compounds 1, 3 and 4 (each within the scatter of the next).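

Putting pyrrolidin-1-yl in place of cyclopentyl on a sulfonyl sulfur gives a 3.0-fold higher number from compound 2 to compound 4 (0.48 log units; beyond the scatter) in this assay. Within the data shown here, this is the first sign that the place on the sulfonyl sulfur can also move this number, and the step is modest, like those seen earlier among the groups on an aromatic carbon. It comes from an exchange of one ring carbon for nitrogen, with the heavy-atom count and the counted hydrogen-bond donors and acceptors unchanged, and nothing available accounts for the rise. The compounds shown leave open whether a morpholin-4-yl group or an open-chain dimethylamino group on the sulfonyl sulfur would give a similar step. They also leave open whether the same exchange would hold with hydrogen or chloro in place of fluoro on the aromatic carbon.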